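The compounds below may be only part of what the source reports. "The series", "measured", "known", "first", "only" and "open" are said of these compounds alone.

Measured so far in an assay on membranes from CHO cells for displacement of a labelled ligand from adenosine receptor A1 (Homo sapiens), read by scintillation counting, with a stated time of 60 min, tested at 1 uM; on this read-out higher numbers stand for more inhibition at the one concentration tested (going by the name of the read-out) and lower numbers for less inhibition:
- compound 1 `CC1=C(C(=O)OCC(C)C)C(c2cccs2)NC(=O)N1` gives 25%
- compound 2 `CCN(CC)C(=O)C1=C(C)NC(=O)NC1c1cccs1` gives 13%
- compound 3 `CC1=C(C(=O)SC(C)C)C(c2cccs2)NC(=O)N1` gives 1%

Compound 3 holds the lowest of these three numbers; the nearer gap is a number 12 percentage points lower from compound 2 to compound 3 (beyond the scatter) and the wider one is a number 24 percentage points lower from compound 1 to compound 3 (beyond the scatter). Compound 4 `CC1=C(C(=O)OC2CCCC2)C(c2cccs2)NC(=O)N1` differs from compound 3 in one place: cyclopentyloxy in place of isopropylsulfanyl on a carbonyl carbon. The step that bears on this most is a number 24 percentage points lower from compound 1 to compound 3 (beyond the scatter), since compound 1 also carries an alkoxy group on that carbonyl carbon and swapping it for isopropylsulfanyl lowered the read-out; cyclopentyloxy restores an alkoxy group, so a rise of roughly that size is expected. Compound 4 is therefore estimated at 22%, with a range from 8% to 38%. That corresponds to an expected step of a number 21 percentage points higher from compound 3 to compound 4 (beyond the scatter).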

Compound 4, a percentage reported as inhibition, at one concentration (the size of the read-out at that concentration, not a potency): 9%
The estimate for compound 4 lay 13 percentage points above the measured number; the range from low to high includes it.
By their numbers in this assay, from the lowest: compounds 3, 4 and 2 (each within the scatter of the next, the first and the last beyond it); then compound 1.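

In this assay, an alkoxy group on this carbonyl carbon does not by itself keep the read-out up: cyclopentyloxy cannot be told apart from isopropylsulfanyl, with a number 8 percentage points higher from compound 3 to compound 4 (within the scatter), or from diethylamino, with a number 4 percentage points lower from compound 2 to compound 4 (within the scatter). The choice of alkoxy group matters, since cyclopentyl in place of isobutyl on that oxygen gives a number 16 percentage points lower from compound 1 to compound 4 (beyond the scatter). No evidence here explains this difference. Still open, going by these compounds, is how a benzyloxy group, a longer chain such as hexyloxy or a free carboxylic acid would read at this position.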